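The compounds below may be only part of what the source reports. "The series", "measured", "known", "first", "only" and "open" are said of these compounds alone.

For the measured compounds named here, compound 3 `COc1ccc(Oc2ccc3c(NCCCNCc4cccc(OC)c4O)ccnc3c2)cc1` gives 14500 nM in a physicochemical assay for solubility, with a stated time of 18 h, at pH 7.4 (a higher number here means a more soluble compound, a lower number a less soluble compound), the highest of the three numbers measured so far. Compound 1 `COc1cccc(CNCCCNc2ccnc3cc(Cc4cc(C)cc(C)c4)ccc23)c1O` gives 4200 nM in this assay, and compound 2 `COc1cccc(CNCCCNc2ccnc3cc(Cc4ccc(F)cc4)ccc23)c1O` gives 4200 nM. The steps of a 3.5-fold higher number from compound 1 to compound 3 (0.54 log units; beyond the scatter) and a 3.5-fold higher number from compound 2 to compound 3 (0.54 log units; beyond the scatter) both set compound 3 apart from the other two, while the step of no change at the digits printed from compound 1 to compound 2 (within the scatter) stays within the scatter.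

Compound 4 `COc1cccc(CNCCCNc2ccnc3cc(Oc4cccc(N(C)C)c4)ccc23)c1O` differs from compound 3 in one place: 3-(dimethylamino)phenyl in place of 4-methoxyphenyl on an oxygen on an aromatic ring. Going by the values given here, none of the measured steps alters the group on that ether oxygen; the two steps that lead to compound 3 replace a benzyl group with an aryloxy group on the core, and the remaining step swaps one benzyl ring for another. The change to compound 4 is therefore of a kind not yet sampled, and no step beyond the scatter can be predicted from these numbers in either direction. The expected step in this assay is a 1.0-fold lower number from compound 3 to compound 4 (0.02 log units; within the scatter), and the expected solubility of compound 4 is 14000 nM, with a range from 5000 nM to 40000 nM.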

Compound 4, solubility: 14500 nM
Compound 4: middle estimate off by 1.0-fold (0.02 log units), on the low side; the measured number falls inside the stated range.
By their numbers in this assay, from the lowest: compounds 1 and 2 (each within the scatter of the next); then compounds 3 and 4 (each within the scatter of the next).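

In this assay, the change on the oxygen from 4-methoxyphenyl to 3-(dimethylamino)phenyl gives no change at the digits printed from compound 3 to compound 4 (within the scatter) and so shows that this position can take a different substituted phenyl with no step beyond the scatter in this one pair. The gap to the benzyl compounds recurs in a 3.5-fold higher number from compound 2 to compound 4 (0.54 log units; beyond the scatter) and in a 3.5-fold higher number from compound 1 to compound 4 (0.54 log units; beyond the scatter) and now holds for two aryloxy groups, 4-methoxyphenoxy and 3-(dimethylamino)phenoxy, rather than one.

The compounds shown leave open whether a phenyl ring bearing a carboxylic acid, or a cyclohexyl ring on that oxygen, would move the number. They also leave open whether the gap would persist between unsubstituted phenoxy and benzyl groups on the core. No measurement given here accounts for these numbers.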